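The compounds below may be only part of what the source reports. "The series", "measured", "known", "first", "only" and "open" are said of these compounds alone.

Working notes on the series, read in a functional assay on HL-60 cells (Homo sapiens) for inhibition, read by CCK-8 assay, with a stated time of 48 h; on this read-out lower numbers stand for stronger inhibition and higher numbers for weaker inhibition. Compound 1 `COc1ccc(NC(=O)NCCNS(=O)(=O)c2sccc2-c2ccc(C)cc2Oc2ccc(O)c(O)c2)cc1` gives 6100 nM, compound 2 `Cc1ccc(-c2ccsc2S(=O)(=O)NCCNC(=O)Nc2ccc([N+](=O)[O-])cc2)c(Oc2ccc(O)c(O)c2)c1` gives 3900 nM, and compound 3 `Cc1ccc(-c2ccsc2S(=O)(=O)NCCNC(=S)Nc2ccc([N+](=O)[O-])cc2)c(Oc2ccc(O)c(O)c2)c1` gives 2900 nM. The gap of a 1.3-fold lower number from compound 2 to compound 3 (0.13 log units; within the scatter) lies within the scatter, while a 2.1-fold lower number from compound 1 to compound 3 (0.32 log units; beyond the scatter) lies just beyond it, a modest step. For the measured compounds named here, compound 3 therefore stands level with compound 2 at the low end of the numbers so far.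

Compound 4 `Cc1ccc(-c2ccsc2S(=O)(=O)NCCNC(=S)Nc2cccc([N+](=O)[O-])c2)c(Oc2ccc(O)c(O)c2)c1` differs from compound 3 as follows: 3-nitrophenyl in place of 4-nitrophenyl on an amide-type nitrogen. In short, 3-nitrophenyl stands in place of 4-nitrophenyl on an amide-type nitrogen. Going by the values given here, no measured pair tests this change directly. Among the compounds with values here, the closest evidence is the one change measured on this aromatic ring, a 1.6-fold lower number from compound 1 to compound 2 (0.19 log units; within the scatter), which stayed within the scatter. No step beyond the scatter is therefore expected in this assay. The expected step is a 1.1-fold higher number from compound 3 to compound 4 (0.04 log units; within the scatter). For compound 4 the estimate is 3200 nM, with an expected range of 1600 nM to 6400 nM.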

Compound 4, half-maximal inhibitory concentration: 3400 nM
Beside the measured number, compound 4's estimate is 1.1-fold (0.03 log units) below it; the range from low to high includes it.
By their numbers in this assay, from the lowest: compounds 3, 4, 2 and 1 (each within the scatter of the next, the first and the last beyond it).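

First direct test of this position: in this assay, 3-nitrophenyl in place of 4-nitrophenyl on the amide-type nitrogen gives a 1.2-fold higher number from compound 3 to compound 4 (0.07 log units; within the scatter), so moving the nitro group on this ring does not separate the two compounds. The other new steps, a 1.1-fold lower number from compound 2 to compound 4 (0.06 log units; within the scatter) and a 1.8-fold lower number from compound 1 to compound 4 (0.25 log units; within the scatter), also stay within the scatter, whereas a 2.1-fold lower number from compound 1 to compound 3 (0.32 log units; beyond the scatter) lay just beyond it, so the one gap beyond the scatter in this set is not repeated with 3-nitrophenyl. No supporting data are available to explain these small steps.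

From the compounds shown here alone, whether an amine or a carboxylic acid in place of the nitro group would give a step beyond the scatter remains open. Going by these compounds, the effect of a longer chain in place of the one joining the sulfonamide and the thiocarbonyl group also remains open.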